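Swapping the triazole aryl group on an unmeasured analogue

A few compounds are considered here, and "the series" means these few. Any claim that something is new, unique, unknown or untested is made for them only; others in the source may bear on it.

Compound 1, `C=C1C[C@]23C[C@@]1(O)CC[C@H]2c1ccc(O)c(C)c1[C@@H]3Cn1cc(-c2ccccn2)nn1`: in a functional assay on SMMC-7721 cells (Homo sapiens) for cytotoxicity, read by MTT assay, with a stated time of 4 days (a lower number here means a stronger inhibitor, a higher number a weaker inhibitor), compound 1 gives > 20000 nM, which is a limit of the assay and not a number.
Compound 2, `C=C1C(=O)[C@]23C[C@@]1(O)CC[C@H]2c1ccc(O)c(C)c1[C@@H]3Cn1cc(-c2ccc(F)cc2)nn1`: in this assay compound 2 gives 850 nM.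
Compound 3, `C=C1C[C@]23C[C@@]1(O)CC[C@H]2c1cc(Br)c(O)c(C)c1[C@@H]3Cn1cc(-c2ccccn2)nn1`: in this assay compound 3 gives > 20000 nM, again a limit of the assay and not a number.

Going by the values given here, compound 1 therefore stands only at a limit in this assay, and so does compound 3, so that the single one-place step, a step that the two limits leave unreadable from compound 1 to compound 3, cannot be read; both sit at the limit of > 20000 nM in this assay, at which 2 of the 3 values shown sit. Among the compounds with values here, compound 2 differs from compound 1 in two places, one of them a carbonyl, so its value shows only that a related compound can reach a measurable number.

Compound 4, `C=C1C[C@]23C[C@@]1(O)CC[C@H]2c1ccc(O)c(C)c1[C@@H]3Cn1cc(-c2ccc(Cl)cc2)nn1`, is not yet measured. It differs from compound 1 in one place: 4-chlorophenyl in place of pyridin-2-yl on an aromatic carbon. Within the data shown here, no measured step touches this change, so the expectation rests on compound 1 alone. Compound 4 is expected to give 8000 nM in this assay, within 1500 nM to 40000 nM, with a fair chance that only a limit is reported again. The step that this estimate means is an at least 2.5-fold lower number from compound 1 to compound 4 (0.39 log units; beyond the scatter), expected rather than known.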

Compound 4, half-maximal inhibitory concentration: > 20000 nM
Compound 4 gave a limit, no number (the forecaster's own chance of this, stated with the estimate: 45%); at least 2.5-fold (0.39 log units) between middle value and limit.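

Compound 1 and compound 4 both stand at a limit of the assay and not at a number, so the swap of pyridin-2-yl for 4-chlorophenyl gives no step that can be read: the limit of > 20000 nM in this assay, at which 3 of the 4 values shown sit.

The compounds shown leave open whether this swap changes the number in this assay at all, and by how much.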